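The source may report more compounds than this note shows. Statements on the series, on what has been measured and on what is new or still open speak of the compounds shown alone.

Measured compounds in a functional assay on KYSE-450 cells (Homo sapiens) for inhibition, read by MTT assay, with a stated time of 48 h; on this read-out higher numbers stand for weaker inhibition and lower numbers for stronger inhibition:
- compound 1 `C/C=C/C(=O)N(Cc1ccc(OC)c(C)c1)c1cc(OC)c(OC)c(OC)c1`: 32900 nM
- compound 2 `C/C=C/C(=O)N(Cc1ccc(OC)c(N)c1)c1cc(OC)c(OC)c(OC)c1`: 310 nM
- compound 3 `C/C=C/C(=O)N(Cc1ccc(OC)c([N+](=O)[O-])c1)c1cc(OC)c(OC)c(OC)c1`: 510 nM

Compound 3 stands second highest of the three numbers. Its nearest neighbour is compound 2, at a 1.6-fold higher number from compound 2 to compound 3 (0.22 log units; within the scatter), within the scatter; the furthest is compound 1, at a 65-fold lower number from compound 1 to compound 3 (1.81 log units; beyond the scatter).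

Compound 4 `C/C=C/C(=O)N(Cc1ccc(OC)c(F)c1)c1cc(OC)c(OC)c(OC)c1` is the next compound. The change from compound 3 is fluoro in place of nitro on an aromatic carbon.

Going by the values given here, two measured steps bear on this position. The step of a 65-fold lower number from compound 1 to compound 3 (1.81 log units; beyond the scatter) shows that the group here can move the number a long way; the step of a 1.6-fold higher number from compound 2 to compound 3 (0.22 log units; within the scatter) shows that nitro and amino give much the same number. Among the compounds with values here, no measured step introduces fluoro, so the direction is uncertain, but a move back toward compound 1 is expected: for compound 4 the estimate is a 7.8-fold higher number from compound 3 to compound 4 (0.89 log units; beyond the scatter), giving 4000 nM with a range of 600 nM to 30000 nM.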

Compound 4, half-maximal inhibitory concentration: 1400 nM
The estimate for compound 4 lay 2.9-fold (0.46 log units) above the measured number, and the stated range covers the measured number.
By their numbers in this assay, from the lowest: compounds 2 and 3 (each within the scatter of the next); then compound 4; then compound 1.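

In this assay, fluoro on this aromatic carbon, ortho to a methoxy group, reads apart from both nitro (a 2.7-fold higher number from compound 3 to compound 4 (0.44 log units; beyond the scatter)) and amino (a 4.5-fold higher number from compound 2 to compound 4 (0.65 log units; beyond the scatter)). Fluoro still stays well clear of methyl (a 24-fold lower number from compound 1 to compound 4 (1.37 log units; beyond the scatter)), so the four groups now fall on three levels rather than two, with nitro and amino together at the low end. No measurement bearing on why the groups fall in this order is available. The compounds shown leave open how a hydroxyl, a chlorine atom or a dimethylamino group would read at this position.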